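The compounds below may be only part of what the source reports. "The series", "measured", "known", "first", "only" and "open" are said of these compounds alone.

Three compounds share one core and differ in a single place, the group on an aromatic carbon. Compound 1 `Cc1ccc(-c2cc(N3CCC(CCNS(N)(=O)=O)CC3)ncn2)cc1` carries a methyl there and in a functional assay on MCF7 cells (Homo sapiens) for antiproliferative activity, read by sulforhodamine B assay, with a stated time of 48 h (a lower number here means a stronger inhibitor of growth, a higher number a weaker inhibitor of growth), compound 1 gives 47500 nM. Compound 2 `CCCCc1ccc(-c2cc(N3CCC(CCNS(N)(=O)=O)CC3)ncn2)cc1` carries a butyl, and in this assay compound 2 gives 11300 nM. Compound 3 `CC(C)(C)c1ccc(-c2cc(N3CCC(CCNS(N)(=O)=O)CC3)ncn2)cc1` carries a tert-butyl, and in this assay compound 3 gives 13100 nM.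

Compound 3 holds the second highest of the three numbers. The step of a 3.6-fold lower number from compound 1 to compound 3 (0.56 log units; beyond the scatter) separates it from its furthest neighbour, while the step of a 1.2-fold higher number from compound 2 to compound 3 (0.06 log units; within the scatter) leaves it and its nearest neighbour within the scatter.

Compound 4 `NS(=O)(=O)NCCC1CCN(c2cc(-c3ccc(C(F)(F)F)cc3)ncn2)CC1` has not yet been measured. Its change from compound 3 is trifluoromethyl in place of tert-butyl on an aromatic carbon. All three measured steps alter the same group: a 4.2-fold lower number from compound 1 to compound 2 (0.62 log units; beyond the scatter) and a 3.6-fold lower number from compound 1 to compound 3 (0.56 log units; beyond the scatter) are modest, and a 1.2-fold higher number from compound 2 to compound 3 (0.06 log units; within the scatter) is within the scatter. None of them involves fluorine, and the entering group matches the leaving one in heavy-atom count, so the data give no ground for a large move in either direction. The expected step is therefore a 1.1-fold higher number from compound 3 to compound 4 (0.06 log units; within the scatter), not beyond the scatter. Compound 4 is estimated at 15000 nM in this assay, with a range from 6000 nM to 40000 nM.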

Compound 4, concentration for 50% growth inhibition: 15200 nM
For compound 4 the middle estimate is 1.0-fold (0.01 log units) below the measured one; the measured number falls inside the stated range.
By their numbers in this assay, from the lowest: compounds 2, 3 and 4 (each within the scatter of the next); then compound 1.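

Among these compounds, compound 4 is the first to carry fluorine at this position, yet in this assay it cannot be told apart from the two other compounds with larger groups, with a 1.2-fold higher number from compound 3 to compound 4 (0.06 log units; within the scatter) and a 1.3-fold higher number from compound 2 to compound 4 (0.13 log units; within the scatter). It also shares their separation from the methyl compound, with a 3.1-fold lower number from compound 1 to compound 4 (0.49 log units; beyond the scatter), so among these four compounds, methyl alone stands apart. Replacing the four carbons of tert-butyl with one carbon and three fluorine atoms keeps the heavy-atom count the same and moves the result by no more than the scatter, but nothing measured here accounts for this.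

The compounds shown leave open whether a methoxy group, an amine or a carboxylic acid at this position would stay with the butyl, tert-butyl and trifluoromethyl compounds or would give a number closer to that of compound 1. They also leave open whether a chain longer than butyl would move the number beyond the scatter, and whether this trifluoromethyl result would hold on a different core.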